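Swapping Configuration at the Saturated Ring of Compound 1

The source may report more compounds than this note shows. Statements on the series, on what has been measured and on what is new or still open speak of the compounds shown alone.

Compound 1 `COCC[C@H]1C[C@@H]1c1cncc(N2C[C@@H]3C[C@H]2CN3)c1` was examined in an assay on a protein complex for displacement of a labelled ligand from Neuronal acetylcholine receptor; alpha4/beta4 (Rattus norvegicus), read by scintillation counting (on this read-out higher numbers stand for weaker inhibition and lower numbers for stronger inhibition), and gives 1340 nM. Of the two measured compounds it holds the higher number: compound 2 `c1cncc(N2CC3CC2CN3)c1`, the shared core without the substituted ring, gives 7.7 nM in this assay, and the gap between the two lies well beyond the usual scatter. For the measured compounds named here, no step between measured compounds that differ in a single place is at hand, so the data say nothing directly about how configuration at the saturated ring bears on affinity.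

Compound 3 `COCC[C@@H]1C[C@H]1c1cncc(N2C[C@@H]3C[C@H]2CN3)c1` is the next member. It differs from compound 1 as follows: the two compounds have the same atoms and bonds and differ only in configuration as drawn: 2 of 4 stereo elements differ; a stereocentre at a saturated ring carbon is drawn R in compound 1 and S in compound 3; a stereocentre at a saturated ring carbon is drawn S in compound 1 and R in compound 3. The other two stereo elements keep their configuration. Because compound 1 gives 1340 nM while compound 2 gives 7.7 nM, there is room for movement in either direction, and a change of configuration at the saturated ring could reasonably be felt as a moderate step. The step from compound 1 to compound 3 is expected to be a 1.9-fold lower number from compound 1 to compound 3 (0.28 log units; within the scatter), with slightly more weight on a lower number. Compound 3 is therefore estimated at 700 nM, with a range from 120 nM to 4000 nM.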

Compound 3, inhibition constant: 8450 nM
Estimate against measurement, compound 3: 12-fold (1.08 log units) below, and the stated range ends below it.
By their numbers in this assay, from the lowest: compound 2; then compound 1; then compound 3.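

For the compounds shown here, the pair gives the first direct reading of this position: in this assay inverting the two saturated ring carbons, with the other two stereo elements kept as drawn, brings a 6.3-fold higher number from compound 1 to compound 3 (0.80 log units; beyond the scatter) and so weakens inhibition by a step that lies beyond the usual scatter. Going by these compounds alone, until now no two measured compounds differed in a single place, so nothing tied the read-out to the configuration of this ring; of the two arrangements, the one drawn in compound 1 now proves the stronger on this receptor. Nothing else in the structure moves, so the step belongs to configuration alone: the fact that compounds 1 and 3 differ only in the configuration as drawn.

The two ring carbons changed together, so the compounds shown do not tell whether one of them carries the step or both share it, and the arrangements with only one of the two carbons inverted remain unknown. Nor do they tell whether the same preference would hold if the chain on the saturated ring were replaced by a longer chain or ended in an amine or a carboxylic acid.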